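The compounds below may be only part of what the source reports. "The series", "measured", "known", "first", "only" and "open" are said of these compounds alone.

Compound 1 `Cc1ccc(NC2=CC(=O)c3c(nc4n3[C@H]3OC[C@@H](O)[C@H]3OC4)C2=O)cc1C` and compound 2 `CCOc1ccccc1NC1=CC(=O)c2c(nc3n2[C@H]2OC[C@@H](O)[C@H]2OC3)C1=O` share their core with compound 3 `O=C1C(NC2CCCCC2)=CC(=O)c2c1nc1n2[C@H]2OC[C@@H](O)[C@H]2OC1` and with the not yet measured compound 4 `O=C1C(Nc2ccc(Br)cc2)=CC(=O)c2c1nc1n2[C@H]2OC[C@@H](O)[C@H]2OC1`. In a functional assay on ECa-109 cells for inhibition, with ECa-109 cell line (Homo sapiens) as the target, read by sulforhodamine B assay (a higher number here means a weaker inhibitor, a lower number a stronger inhibitor), compound 1 gives 4090 nM, and compound 2 gives 4320 nM. Within the data shown here, compound 3 reaches only the limit of this assay, > 16000 nM, and so stands as the one compound here with a limit rather than a number (the limit of > 16000 nM in this assay, at which 1 of the 3 values shown sits). The change to compound 4 is 4-bromophenyl in place of cyclohexyl on an amine nitrogen. Among the measured compounds shown here, the steps that bear on it run the other way: an at least 3.9-fold higher number from compound 1 to compound 3 (0.59 log units; beyond the scatter) and an at least 3.7-fold higher number from compound 2 to compound 3 (0.56 log units; beyond the scatter). Undoing such a change, a lower number is expected, of about an at least 3.5-fold lower number from compound 3 to compound 4 (0.55 log units; beyond the scatter). Compound 4 is estimated at 4500 nM, within a range of 1500 nM to 13000 nM.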

Compound 4, half-maximal inhibitory concentration: 1980 nM
Beside the measured number, compound 4's estimate is 2.3-fold (0.36 log units) above it; measured number inside the range.
By their numbers in this assay, from the lowest: compound 4; then compounds 1 and 2 (each within the scatter of the next). At a limit, above all of these: compound 3.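

Among the aryl groups on this amine nitrogen, 4-bromophenyl is the first to separate from the others in this assay (a 2.2-fold lower number from compound 2 to compound 4 (0.34 log units; beyond the scatter); a 2.1-fold lower number from compound 1 to compound 4 (0.32 log units; beyond the scatter)), whereas compounds 1 and 2 lay within the scatter of each other. Set against cyclohexyl, the same group gives the largest step seen at this position (an at least 8.0-fold lower number from compound 3 to compound 4 (0.90 log units; beyond the scatter)). That step has only a lower bound, since compound 3 remains a limit and not a number: the limit of > 16000 nM in this assay, at which 1 of the 4 values shown sits.

Going by these compounds, whether the bromine itself matters stays open, and a 4-chlorophenyl, an unsubstituted phenyl or a benzyl group on this nitrogen would bear on that.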